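A Sulfonyl Group Added to Compound 2

This account rests on a few compounds, and the source may have more. Where it says the series, first, only, none or still open, it means among the compounds named here.

Compound 1 `Cc1ccc(-c2nn(-c3ccccc3)cc2-c2nc3ccccc3[nH]2)cc1`: > 300000 nM (a limit of the assay)
Compound 2 `FC(F)(F)c1ccc(-c2nn(-c3ccccc3)cc2-c2nc3ccccc3[nH]2)cc1`: 159000 nM
Compound 3 `O=S(=O)(c1ccccc1)n1c(-c2cn(-c3ccccc3)nc2-c2ccc(F)cc2)nc2ccccc21`: 231000 nM

In an ADME assay on cells (Hepatocyte, Mus musculus) for cytotoxicity, read by MTT assay, with a stated time of 24 h (a higher number here means that more compound is tolerated, a lower number that less compound is tolerated), compound 2 gives 159000 nM. Among the measured compounds shown here, only one other compound has a true number: compound 3 gives 231000 nM, and the two values lie within the scatter of each other. Compound 1 gives > 300000 nM, which is a limit of the assay.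

Compound 4 `COc1ccc(S(=O)(=O)n2c(-c3cn(-c4ccccc4)nc3-c3ccc(C(F)(F)F)cc3)nc3ccccc32)cc1` is built from compound 2 by one change, (4-methoxyphenyl)sulfonyl in place of hydrogen on an aromatic nitrogen. For the measured compounds named here, the single measured step, an at least 1.8-fold lower number from compound 1 to compound 2 (0.27 log units; that floor lies within the scatter), concerns trifluoromethyl in place of methyl on an aromatic carbon, so it does not test this change. Its size is also only a floor. Going by the values given here, the nearest guide is compound 3, the one measured compound with a sulfonyl group, at 231000 nM. On that basis no shift beyond the scatter is expected in this assay. The expected change is a 1.1-fold higher number from compound 2 to compound 4 (0.03 log units; within the scatter). For compound 4 the estimate is 170000 nM, with an expected range from 90000 nM to 300000 nM.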

Compound 4, half-maximal cytotoxic concentration: 87400 nM
For compound 4 the middle estimate is 1.9-fold (0.29 log units) above the measured one; the whole stated range lies above it.
By their numbers in this assay, from the lowest: compounds 4, 2 and 3 (each within the scatter of the next, the first and the last beyond it). At a limit, above all of these: compound 1.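

Among the compounds shown here, compound 4 gives the first direct reading of a substituent on the aromatic nitrogen of the five-membered aromatic ring: in this assay, placing (4-methoxyphenyl)sulfonyl there instead of hydrogen gives a 1.8-fold lower number from compound 2 to compound 4 (0.26 log units; within the scatter). The hydrogen on this nitrogen can therefore be replaced by this sulfonyl group without a shift beyond the scatter, and compound 4 still gives a true number rather than a limit. Unlike the earlier step, whose size was only a floor, this step has a true number at each end, whereas compound 1 stands at a limit of the assay: the limit of > 300000 nM in this assay, at which 1 of the 4 values shown sits.

The compounds shown leave open how much of this reading belongs to the sulfonyl link and how much to the 4-methoxyphenyl part, and how a methanesulfonyl group, an acetyl group or a plain methyl on the same nitrogen would read. They also leave open how the same sulfonyl change would read with the methyl of compound 1 in place of trifluoromethyl, and compound 3 cannot settle either question, since it differs from compound 4 in more than one place.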